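This account rests on a few compounds, and the source may have more. Where it says the series, first, only, none or still open, it means among the compounds named here.

Two compounds of one series have been examined in a functional assay on HT-29 cells (Homo sapiens) for cytotoxicity, read by MTT assay, with a stated time of 72 h; on this read-out higher numbers stand for weaker inhibition and lower numbers for stronger inhibition. Compound 1, `CN(C)CCn1cnnc1-c1cc(Oc2ccc(NC(=O)N/N=C/c3c(Cl)cccc3Cl)cc2F)ccn1`, gives 280 nM in this assay. Compound 2, `CN(C)CCn1cnnc1-c1cc(Oc2ccc(NC(=O)N/N=C/c3cc(C(C)(C)C)cc(C(C)(C)C)c3O)cc2F)ccn1`, gives 680 nM in this assay. Among these two numbers compound 1 stands lowest, and the gap to compound 2 lies beyond the usual scatter, so compound 1 is the stronger inhibitor of the pair.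

Compound 3, `COc1ccc(OC)c(/C=N/NC(=O)Nc2ccc(Oc3ccnc(-c4nncn4CCN(C)C)c3)c(F)c2)c1`, has not yet been measured in this assay. It is related to compound 1 by a single change: 2,5-dimethoxyphenyl in place of 2,6-dichlorophenyl on a carbon with a double bond to nitrogen. Among the measured compounds shown here, nothing among the measured compounds shows what this particular change does, because no step from a measured compound carries it; the only hint is that compound 2, which likewise replaces the 2,6-dichlorophenyl with another aryl group, gives 680 nM.

On that basis the step of a 1.8-fold higher number from compound 1 to compound 3 (0.25 log units; within the scatter) is expected to be a modest move towards a higher number, of a size that may or may not clear the scatter. The estimate for compound 3 in this assay is therefore 500 nM, with a plausible range from 150 nM to 1700 nM.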

Compound 3, half-maximal inhibitory concentration: 2070 nM
Estimate against measurement, compound 3: 4.1-fold (0.62 log units) below; measured number above the stated range.
By their numbers in this assay, from the lowest: compound 1; then compound 2; then compound 3.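

Among the compounds shown here, with the rest of the structure unchanged, 2,5-dimethoxyphenyl in place of 2,6-dichlorophenyl on a carbon with a double bond to nitrogen gives a 7.4-fold higher number from compound 1 to compound 3 (0.87 log units; beyond the scatter) in this assay, the first direct reading of a single change at this position, and it shows that the number depends clearly on which aryl group sits there. Replacing the 2,6-dichlorophenyl also does not lead to one common value: compound 2 gives 680 nM, while compound 3 gives 2070 nM. The entering group carries oxygen and the leaving group chlorine, but no measurement shown accounts for the rise in the number.

One step cannot separate the effect of removing the chlorine atoms from that of adding the methoxy groups, nor show whether the arrangement of the methoxy groups on the ring matters. An unsubstituted phenyl would give the missing reference point at this position, and a phenyl carrying a single methoxy group or a carboxylic acid would show how far the number follows the substituent, which the compounds shown leave open.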